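Esterification at the acid of compound 2: expected effect

The source may hold more compounds than are shown below. What is called first, only, known or untested is meant among the compounds shown, and "the series" means these compounds.

Three compounds of the series have numbers in a functional assay on the whole organism (strain Hart Swiss) with Mus musculus as the target, with stated times of 5 days and 2 weeks, at a dose of 5 mg/kg by the intraperitoneal route; on this read-out lower numbers stand for a weaker effect and higher numbers for a stronger effect at the one dose given. Compound 1 `COc1cc(C)c(/C=C/C(C)=C/C=C(F)/C(C)=C/C(=O)O)c(C)c1C` gives 63%. Compound 2 `COc1cc(C)c(/C=C/C(C)=C(F)/C=C/C(C)=C/C(=O)O)c(C)c1C` gives 30%, the lowest of the three, beyond the scatter from each of the others. Compound 3 `CCOC(=O)/C=C(C)/C(F)=C/C=C(C)/C=C/c1c(C)cc(OC)c(C)c1C` gives 43%. Within the data shown here, the single step between compounds differing in one place is a number 20 percentage points lower from compound 1 to compound 3 (beyond the scatter), ethyl in place of hydrogen on an oxygen next to a carbonyl group.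

Compound 4 `COC(=O)/C=C(C)/C=C/C(F)=C(C)/C=C/c1c(C)cc(OC)c(C)c1C` is not yet measured. It differs from compound 2 by methyl in place of hydrogen on an oxygen next to a carbonyl group. The step from compound 1 to compound 3 is the nearest measured case, an alkyl group on the same kind of oxygen, and it gave a drop beyond the scatter. Compound 2 already stands low, so a drop of comparable size would bring the number close to the floor of the read-out. On this basis compound 4 is expected to come out below compound 2, with a number 15 percentage points lower from compound 2 to compound 4 (beyond the scatter) as the expected step. Compound 4 is estimated at 15%, in the range 0% to 40%.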

Compound 4, a percentage reported as activity, at one dose (the size of the read-out at that dose, not a potency): 28%
Compound 4: middle estimate off by 13 percentage points, on the low side; low and high end bracket the measured number.
By their numbers in this assay, from the lowest: compounds 4 and 2 (each within the scatter of the next); then compound 3; then compound 1.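

In this assay, methyl in place of hydrogen on an oxygen next to a carbonyl group gives a number 2 percentage points lower from compound 2 to compound 4 (within the scatter), so on the acid of compound 2 this change leaves the read-out level at this dose. The earlier ester step, a number 20 percentage points lower from compound 1 to compound 3 (beyond the scatter), therefore does not hold for every alkyl group on this kind of oxygen in every parent acid: the loss seen with ethyl on compound 1 does not recur with methyl on compound 2. No measurement on hand explains the difference between these two steps.

Still open, from the compounds shown here alone, is whether the difference follows the alkyl group or the parent acid, as the two steps differ in both. Also open, going by these compounds, is how a longer chain such as propyl, or an amide in place of the ester, would read at this oxygen-bearing carbonyl.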